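Nitrone series on A549: benzyl to tert-butyl

The source may hold more compounds than are shown below. What is called first, only, known or untested is meant among the compounds shown, and "the series" means these compounds.

Three measured compounds and one open one. Compound 1 `COc1ccc(-n2cc(/C=[N+](\[O-])Cc3ccccc3)nn2)cc1` carries a benzyl group on the nitrone nitrogen; in a functional assay on A549 cells (Homo sapiens) for inhibition, read by MTT assay, with a stated time of 24 h (a higher number here means a weaker inhibitor, a lower number a stronger inhibitor), compound 1 reaches only a limit of the assay, > 100000 nM. Compound 2 `[O-]/[N+](=C\c1cn(CCC(F)(F)C(F)(F)C(F)(F)C(F)(F)C(F)(F)C(F)(F)F)nn1)Cc1ccccc1` carries the same benzyl group on a different core; in this assay compound 2 likewise stops at a limit, > 100000 nM. The difference between the two cores is not broken down here. Compound 3 `COc1ccc(-n2cc(/C=[N+](\[O-])C(C)(C)C)nn2)cc1` gives a number, 23700 nM, in this assay. The change from compound 1 to compound 3 is tert-butyl in place of benzyl on a double-bonded nitrogen, and the step is an at least 4.2-fold lower number from compound 1 to compound 3 (0.62 log units; beyond the scatter); its size is bounded by the limit of > 100000 nM in this assay, at which 2 of the 3 values shown sit.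

Compound 4 `CC(C)(C)/[N+]([O-])=C/c1cn(CCC(F)(F)C(F)(F)C(F)(F)C(F)(F)C(F)(F)C(F)(F)F)nn1` is still to be measured. It differs from compound 2 by tert-butyl in place of benzyl on a double-bonded nitrogen, the same change as from compound 1 to compound 3. In this assay a step of an at least 2.5-fold lower number from compound 2 to compound 4 (0.39 log units; beyond the scatter) is expected, resting on the step of an at least 4.2-fold lower number from compound 1 to compound 3 (0.62 log units; beyond the scatter) and on compound 2 sitting at the limit of > 100000 nM in this assay, at which 2 of the 3 values shown sit. For compound 4 the estimate in this assay is 40000 nM, with a range from 10000 nM to 200000 nM.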

Compound 4, half-maximal inhibitory concentration: 11500 nM
For compound 4 the middle estimate is 3.5-fold (0.54 log units) above the measured one; low and high end bracket the measured number.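

In this assay, tert-butyl in place of benzyl on a double-bonded nitrogen gives, on the core of compound 2, a second step in the same direction as on the core of compound 1 (an at least 8.6-fold lower number from compound 2 to compound 4 (0.93 log units; beyond the scatter)), so across these two cores the change goes with a lower number. This does not show that the change has the same size on both cores, and two cores are too few to support a rule for the series: the same change on two cores in this assay, an at least 4.2-fold lower number (0.62 log units; beyond the scatter) from compound 1 to compound 3 and an at least 8.6-fold lower number (0.93 log units; beyond the scatter) from compound 2 to compound 4; the limit leaves it open whether they differ. Neither step has a measured starting point, so each gives only a minimum size: the limit of > 100000 nM in this assay, at which 2 of the 4 values shown sit.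

Still open, going by these compounds, is how the number would move with an isopropyl or a cyclohexyl group in place of tert-butyl on a double-bonded nitrogen. Also open, on these data alone, is whether the step holds on a core carrying a carboxylic acid, an amine or a longer chain in place of the groups present in these compounds.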